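Swapping 3-phenylpropyl for phenyl on a ring nitrogen

A few compounds are considered here, and "the series" means these few. Any claim that something is new, unique, unknown or untested is made for them only; others in the source may bear on it.

Measured so far in an ADME assay on the whole organism (Rattus norvegicus) for pharmacokinetics, read by LC-MS; a higher number here means that more of the compound sits outside the plasma, a lower number that more of the compound stays in the plasma
Compound 1 `Cc1ccc(-c2c3c(nc(C)c2C(OC(C)(C)C)C(=O)O)CCN(Cc2ccccc2-c2ccccc2)C3)cc1` gives 9 L/kg
Compound 2 `Cc1ccc(-c2c3c(nc(C)c2[C@H](OC(C)(C)C)C(=O)O)CCN(CCCc2ccccc2)C3)cc1` gives 16 L/kg
Compound 3 `Cc1nc2c(c(-c3cc(F)c4c(c3C)CCCO4)c1[C@H](OC(C)(C)C)C(=O)O)CN(CCCc1ccc(F)cc1)CC2` gives 1 L/kg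

Compound 2 lies within the scatter of compound 1 and far above compound 3, which differs from it in more than one place. Compound 4 `Cc1ccc(-c2c3c(nc(C)c2[C@H](OC(C)(C)C)C(=O)O)CCN(c2ccccc2)C3)cc1` keeps the core of compound 2 but has phenyl in place of 3-phenylpropyl on an amine nitrogen in a ring and nothing else changes.

Among the measured compounds shown here, no measured pair isolates this change, and no measured compound carries phenyl on that nitrogen, so any forecast is uncertain. Compound 1 and compound 2 have different groups there yet stay within the scatter of each other, while compound 3 at 1 L/kg shows that much lower values occur among these compounds. A fall beyond the scatter is therefore expected, though this is a judgement rather than a measured trend. The expected step is a 5.3-fold lower number from compound 2 to compound 4 (0.73 log units; beyond the scatter) in this assay on this reasoning. The estimate for compound 4 is 3 L/kg with 0.8 L/kg to 10 L/kg as its expected range.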

Compound 4, volume of distribution at steady state: 3 L/kg
Beside the measured number, compound 4's estimate shows no gap at the digits printed, within the range that was stated.
By their numbers in this assay, from the lowest: compound 3; then compound 4; then compounds 1 and 2 (each within the scatter of the next).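

Among the compounds shown here, this is the first pair here that differs in one place only, so the group on the amine nitrogen in a ring can be read on its own in this assay: phenyl in place of 3-phenylpropyl gives a 5.3-fold lower number from compound 2 to compound 4 (0.73 log units; beyond the scatter) with the rest of the molecule unchanged. The step lies beyond the scatter, so this position alone can shift the number, even though the entering and leaving groups each hold one six-membered aromatic ring of carbon only and differ in size, 6 heavy atoms against 9. Nothing shown here gives a measured reason for the fall.

Still open, from the compounds shown here alone, is whether the fall follows the size of the group or the loss of the chain that links the aromatic ring to the nitrogen. Benzyl or 2-phenylethyl on that nitrogen would help to tell these apart, and a single pair cannot show whether the step holds on other cores.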